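The source may report more compounds than this note shows. Statements on the series, on what has been measured and on what is new or still open speak of the compounds shown alone.

Measured so far:
- compound 1, `COc1ccc(S(=O)(=O)N2CCc3cc(Br)cc(NC(=O)c4ccco4)c32)cc1`: 78 nM
- compound 2, `COc1ccc(S(=O)(=O)N2CCc3cccc(NC(=O)c4cccs4)c32)cc1`: 31 nM

Both compounds were run in a functional assay on MKN-45 cells (Homo sapiens) for cytotoxicity; a lower number here means a stronger inhibitor, a higher number a weaker inhibitor. Compound 2 gives 31 nM, the lower of the two numbers; compound 1 gives 78 nM, and the gap between the two lies beyond the scatter of the method. Compound 1 and compound 2 differ from each other in more than one place, so their two values show only that, and no single step can be read from them.

The next compound in the series is compound 3, `COc1ccc(S(=O)(=O)N2CCc3cccc(NC(=O)c4ccco4)c32)cc1`. Against compound 2 the change is furan-2-yl in place of thiophen-2-yl on a carbonyl carbon. Everything else in the shared core stays as it is.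

Going by the values given here, no measured pair isolates this change, so the expected step rests on the two values alone. The step from compound 2 to compound 3 is expected to be small, a 1.6-fold higher number from compound 2 to compound 3 (0.21 log units; within the scatter), leaning toward a somewhat higher number but not clearly beyond the scatter. For compound 3 in this assay the estimate is 50 nM, with a range from 20 nM to 130 nM.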

Compound 3, half-maximal inhibitory concentration: 10.7 nM
Compound 3: middle estimate off by 4.7-fold (0.67 log units), on the high side; measured number below the stated range.
By their numbers in this assay, from the lowest: compound 3; then compound 2; then compound 1.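

In this assay, the exchange of thiophen-2-yl for furan-2-yl on the carbonyl carbon now has a step of its own, a 2.9-fold lower number from compound 2 to compound 3 (0.46 log units; beyond the scatter), beyond the scatter, even though the two groups match in heavy-atom count and differ only in sulfur against oxygen in the five-membered aromatic ring. The aromatic carbon that carries bromo in compound 1 also responds, with hydrogen in place of bromo giving a 7.3-fold lower number from compound 1 to compound 3 (0.86 log units; beyond the scatter), so both places affect the read-out, and compound 3 stands as the most potent of the three, its steps to the other two both being beyond the scatter. No measurement shown bears on the origin of either step.

From the compounds shown here alone, each change has been read only once, so it remains open whether hydrogen in place of bromo would give a similar step with thiophen-2-yl on the carbonyl carbon, or whether furan-2-yl would keep its advantage with bromo on the aromatic carbon. Also open, going by these compounds, is how a phenyl or pyridin-2-yl group on the carbonyl carbon, or chloro or methyl in place of bromo, would read in this assay.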